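A few compounds are considered here, and "the series" means these few. Any claim that something is new, unique, unknown or untested is made for them only; others in the source may bear on it.

Values measured so far in a functional assay on RAW264.7 cells (Mus musculus) for inhibition, read by Griess assay, with stated times of 3 h and 24 h (a lower number here means a stronger inhibitor, a higher number a weaker inhibitor), each one a limit of the assay and not a number:

Compound 1 `C=C1CC[C@H]2[C@@](C)(CCC(=O)N[C@@]2(C)CO)[C@@H]1/C=C/C1=CCOC1=O`: > 50000 nM
Compound 2 `C=C1CC[C@H]2[C@@](C)(CCC(=O)N[C@@]2(C)COC(=O)[C@@H]2CCCN2)[C@@H]1/C=C/C1=CCOC1=O`: > 50000 nM
Compound 3 `C=C1CC[C@H]2[C@@](C)(CC[C@@H](O)[C@@]2(C)NC=O)[C@@H]1/C=C/C1=CCOC1=O`: > 50000 nM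

Compound 3 is known only through its limit of > 50000 nM, and all the values shown sit at that same limit (the limit of > 50000 nM in this assay, at which 3 of the 3 values shown sit). Compound 4 `C=C1CC[C@H]2[C@@](C)(CC[C@@H](OC(=O)c3ccccc3)[C@@]2(C)NC=O)[C@@H]1/C=C/C1=CCOC1=O` differs from compound 3 as follows: benzoyl in place of hydrogen on an oxygen on a saturated carbon. In words, this is hydroxy to benzoyloxy, with benzoyl in place of hydrogen on an oxygen on a saturated carbon.

Within the data shown here, one measured step bears on this change: a step that the two limits leave unreadable from compound 1 to compound 2. It also replaces hydrogen on an oxygen on a saturated carbon, but it gives no size. With no readable size to carry over, compound 4 is expected to stay at or near the limit in this assay, and any shift would be small and toward stronger inhibition. The expected step is an at least 1.1-fold lower number from compound 3 to compound 4 (0.04 log units; that floor lies within the scatter). For compound 4 the estimated value is 45000 nM, with an expected range of 15000 nM to 80000 nM.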

Compound 4, half-maximal inhibitory concentration: 50000 nM
The estimate for compound 4 lay 1.1-fold (0.05 log units) below the measured number; the range from low to high includes it.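

In this assay, benzoyl in place of hydrogen on an oxygen on a saturated carbon gives a number no higher from compound 3 to compound 4 (the limit leaves the size open). The value of compound 3 is a limit, > 50000 nM, so this step sets a direction and no size. Compound 4, at 50000 nM, is the first compound shown with a number rather than a limit, yet that number matches the figure at which the other compounds stop: the limit of > 50000 nM in this assay, at which 3 of the 4 values shown sit.

The compounds shown leave open whether any other group on this oxygen, such as acetyl, a longer acyl chain or a benzoyl carrying an amine or a carboxylic acid, would move the number clearly away from this figure. They also leave open whether benzoyl on the hydroxy of compound 1 would give a readable value.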